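Double-bond configuration in the step from compound 2

A few compounds are considered here, and "the series" means these few. Any claim that something is new, unique, unknown or untested is made for them only; others in the source may bear on it.

Measured in a functional assay on MCF7 cells (Homo sapiens) for antiproliferative activity, read by sulforhodamine B assay, with a stated time of 72 h; a higher number here means a weaker inhibitor, a lower number a stronger inhibitor:
- compound 1 `FC(F)(F)c1ccc(/C=C\c2cc3ccccc3nc2Cl)cc1`: 4260 nM
- compound 2 `Fc1ccc(/C=C\c2cc3ccccc3nc2Cl)cc1`: 20300 nM

Compound 2 holds the higher number of the pair, 20300 nM, and is the weaker inhibitor. Compound 3 `Fc1ccc(/C=C/c2cc3ccccc3nc2Cl)cc1` differs from it as follows: the two compounds have the same atoms and bonds and differ only in configuration as drawn: 1 of 1 stereo elements differ; a double bond is drawn Z in compound 2 and E in compound 3. Within the data shown here, the only measured step, a 4.8-fold higher number from compound 1 to compound 2 (0.68 log units; beyond the scatter), puts fluoro in place of trifluoromethyl and keeps the double bond unchanged, so it offers only a rough scale. Among the measured compounds shown here, no measured pair tests configuration. In this assay, as far as these compounds go, the direction therefore stays open, with a step of similar size or smaller expected. The estimated result is a 1.2-fold higher number from compound 2 to compound 3 (0.07 log units; within the scatter). For compound 3 the expected value is 24000 nM, with an estimated range of 7000 nM to 80000 nM.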

Compound 3, half-maximal inhibitory concentration: 15100 nM
Estimate against measurement, compound 3: 1.6-fold (0.20 log units) above; measured number inside the range.
By their numbers in this assay, from the lowest: compound 1; then compounds 3 and 2 (each within the scatter of the next).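

In this assay, the first direct test of double-bond configuration gives a 1.3-fold lower number from compound 2 to compound 3 (0.13 log units; within the scatter), so with fluoro on the aromatic carbon, the Z and E drawings are not separated. This step can be read on configuration alone: the fact that compounds 2 and 3 differ only in the configuration as drawn. Configuration therefore adds no difference here comparable to the one seen on exchanging trifluoromethyl for fluoro.

Open, as far as these compounds go, is whether the same holds with trifluoromethyl as the substituent. Also open, from the compounds shown here alone, is how the E series responds to other groups at that aromatic carbon, such as an amine or a carboxylic acid.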